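Notes on a single stereocentre change at compound 3

A few compounds are considered here, and "the series" means these few. Any claim that something is new, unique, unknown or untested is made for them only; others in the source may bear on it.

Measured so far in a physicochemical assay for lipophilicity, at pH 7.4; on this read-out higher numbers stand for higher lipophilicity and lower numbers for lower lipophilicity:
- compound 1 `CN1CCC(S(=O)(=O)c2ccc3nc(NC(=O)NC(=O)c4cc(-n5cccn5)ccc4Cl)sc3c2)CC1` gives 2.3
- compound 2 `CCOc1cc(Cl)c(C(=O)NC(=O)Nc2nc3ccc(CN4CCN(C)CC4)cc3s2)cc1-n1cccn1` gives 3.8
- compound 3 `CCOc1cc(Cl)c(C(=O)Nc2nc3ccc(S(=O)(=O)CCCN4CCN(C)CC4)cc3s2)cc1N1C[C@H](C)O[C@@H](C)C1` gives 3

Compound 3 stands second highest of the three numbers, above compound 1 and below compound 2, with both gaps beyond the scatter. Compound 4 `CCOc1cc(Cl)c(C(=O)Nc2nc3ccc(S(=O)(=O)CCCN4CCN(C)CC4)cc3s2)cc1N1C[C@@H](C)O[C@@H](C)C1` is still unmeasured in this assay. The change is the two compounds have the same atoms and bonds and differ only in configuration as drawn: 1 of 2 stereo elements differ; a stereocentre at a saturated ring carbon is drawn S in compound 3 and R in compound 4, so the two compounds have the same atoms and bonds, and a stereocentre at a saturated ring carbon is drawn S in compound 3 and R in compound 4. Within the data shown here, no measured pair shows a step of this kind. The expectation therefore starts from compound 3 at 3 and assumes no direction. The estimated step of no change at the digits printed from compound 3 to compound 4 (within the scatter) is expected to stay within the scatter. Compound 4 is expected at 3, with an estimated range of 2.6 to 3.4.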

Compound 4, distribution coefficient: 2.7
For compound 4 the middle estimate is 0.30 log units above the measured one; the measured number falls inside the stated range.
By their numbers in this assay, from the lowest: compound 1; then compounds 4 and 3 (each within the scatter of the next); then compound 2.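

In this assay, among these compounds, this is the first step that changes only configuration: a number 0.30 log units lower from compound 3 to compound 4 (within the scatter) is what one stereocentre at a saturated ring carbon, drawn S in compound 3 and R in compound 4, amounts to. The two values stand within the scatter of each other, so this pair shows no readable difference at this position. The comparison is free of any change in atoms or bonds: the fact that compounds 3 and 4 differ only in the configuration as drawn.

From the compounds shown here alone, whether this holds when the other stereocentre changes stays open. Also open, going by these compounds, is how an open-chain amine or a carboxylic acid at this position would read.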